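Methyl to allyl on the aromatic nitrogen

The source may hold more compounds than are shown below. What is called first, only, known or untested is meant among the compounds shown, and "the series" means these compounds.

Among the measured compounds shown here, in an ADME assay on HepG2 2.2.15 cells (Homo sapiens) for cytotoxicity (on this read-out lower numbers stand for higher toxicity in this test and higher numbers for lower toxicity in this test), compound 1 (`O=c1[nH]c2ccc(Cl)cc2c(-c2ccccc2Cl)c1CCO`) gives 380000 nM and compound 2 (`Cn1c(=O)c(CCO)c(-c2ccccc2Cl)c2cc(Cl)ccc21`) gives 34000 nM as the lower of the two numbers so far. Compound 3 (`C=CCn1c(=O)c(CCO)c(-c2ccccc2Cl)c2cc(Cl)ccc21`) differs from compound 2 in one place: vinyl in place of hydrogen on a saturated chain carbon bound to an aromatic nitrogen with vinyl in place of hydrogen on a saturated chain carbon bound to an aromatic nitrogen, so that methyl becomes allyl. For the measured compounds named here, the one measured step bearing on this is an 11-fold lower number from compound 1 to compound 2 (1.05 log units; beyond the scatter) for methyl in place of hydrogen on an aromatic nitrogen. That large step concerns the same nitrogen but does not extend a chain, so it supports only a direction. In this assay a small further lowering is expected, probably within the scatter. The expected step is a 1.4-fold lower number from compound 2 to compound 3 (0.13 log units; within the scatter) on this estimate. For compound 3 the estimated value is 25000 nM with an expected range of 9000 nM to 70000 nM for now.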

Compound 3, half-maximal cytotoxic concentration: 23000 nM
The estimate for compound 3 lay 1.1-fold (0.04 log units) above the measured number; the range from low to high includes it.
By their numbers in this assay, from the lowest: compounds 3 and 2 (each within the scatter of the next); then compound 1.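

In this assay, the methyl-to-allyl change on the aromatic nitrogen gives a 1.5-fold lower number from compound 2 to compound 3 (0.17 log units; within the scatter), so the added vinyl does not separate the two compounds on this read-out. Measured against the hydrogen of compound 1, allyl gives a 17-fold lower number from compound 1 to compound 3 (1.22 log units; beyond the scatter) and methyl gives an 11-fold lower number from compound 1 to compound 2 (1.05 log units; beyond the scatter); both steps lie beyond the scatter, so among these three compounds the clear shift comes with replacing the hydrogen on this nitrogen, while going from methyl to allyl adds no step beyond the scatter. Nothing available on these compounds explains this pattern.

Open, on these data alone, is whether a saturated propyl group would read like allyl, which would show whether the double bond matters here. Also open, as far as these compounds go, is whether a longer chain, a benzyl group or a chain carrying an amine on this nitrogen would stay in the same range.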